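Same Methyl Step on Two Cores, One Estimate

The compounds below may be only part of what the source reports. "The series", "measured", "known", "first", "only" and "open" are said of these compounds alone.

Compound 1 `Cc1ccc(S(=O)(=O)N2C(=O)NCC2c2ccccc2)cc1` gives in a functional assay on SK-MEL-2 cells (Homo sapiens) for cytotoxicity (a lower number here means a stronger inhibitor, a higher number a weaker inhibitor), only > 316000 nM, which is a limit of the measurement rather than a number. Compound 3 `Cc1ccc(C2CNC(=O)N2S(=O)(=O)c2ccc(C)cc2)cc1` gives 234000 nM in this assay. The change between them is methyl in place of hydrogen on an aromatic carbon, and the step of an at least 1.3-fold lower number from compound 1 to compound 3 (0.13 log units; that floor lies within the scatter) is a floor only, because of the limit of > 316000 nM in this assay, at which 1 of the 3 values shown sits. Compound 2 `Cc1ccc(S(=O)(=O)N2CC(c3ccccc3)NC2=O)cc1` gives 2530 nM in this assay, the lowest of the two numbers shown, with compound 3 the nearest at a higher value, beyond the scatter. Compound 2 shares its atoms with compound 1 joined differently; the difference between the two cores is not broken down here. Compound 4 `Cc1ccc(C2CN(S(=O)(=O)c3ccc(C)cc3)C(=O)N2)cc1` carries the same change, (methyl in place of hydrogen on an aromatic carbon). Its step is expected as a 1.3-fold lower number from compound 2 to compound 4 (0.10 log units; within the scatter), resting on the step of an at least 1.3-fold lower number from compound 1 to compound 3 (0.13 log units; that floor lies within the scatter), which sits within the scatter. Compound 4 is estimated at 2000 nM.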

Compound 4, half-maximal inhibitory concentration: > 302000 nM
Compound 4 gave a limit, no number; the forecaster's own chance of this, stated with the estimate: 2%; middle value at least 150-fold (2.17 log units) from the limit.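

In this assay the new step is an at least 110-fold higher number from compound 2 to compound 4 (2.07 log units; beyond the scatter), and it does not match the earlier step on the core of compound 1, so the methyl change did not carry over from one core to the other: the same change on two cores in this assay, an at least 1.3-fold lower number (0.13 log units; that floor lies within the scatter) from compound 1 to compound 3 and an at least 110-fold higher number (2.07 log units; beyond the scatter) from compound 2 to compound 4, at least 160-fold (2.20 log units) apart, beyond the scatter of two such steps Compound 4 stands at a limit and not at a number, so this step is only a floor: the limit of > 302000 nM in this assay, at which 1 of the 4 values shown sits. These two pairs show that the result of this change on one core did not hold on the other, but they do not show why the cores differ or how large the true gap is.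

Going by these compounds, it remains open whether a group other than methyl, such as a methoxy group, a chlorine atom or an amine, would also behave differently on the two cores. On these data alone, a longer chain in place of that methyl is equally open.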